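This account rests on a few compounds, and the source may have more. Where it says the series, first, only, none or still open, it means among the compounds named here.

Compound 1 `Cc1ccc(-n2cc(NC(=O)c3cccc(NS(=O)(=O)c4ccccc4)c3)cn2)cc1` and compound 2 `COc1ccc(-n2cc(NC(=O)c3cccc(NS(=O)(=O)c4ccccc4)c3)cn2)cc1` share one core and differ in a single spot, where compound 2 carries methoxy in place of methyl on an aromatic carbon. In a functional assay on HeLa cells (Homo sapiens) for inhibition, read by MTT assay, with a stated time of 48 h (on this read-out lower numbers stand for stronger inhibition and higher numbers for weaker inhibition), compound 1 gives 3120 nM, and compound 2 gives 42200 nM, so that a 14-fold higher number from compound 1 to compound 2 (1.13 log units; beyond the scatter). Compound 3 `Cc1ccc(-n2cc(NC(=O)c3cccc(NS(=O)(=O)c4ccc(Cl)cc4)c3)cn2)cc1` keeps the core of compound 1 with chloro in place of hydrogen on an aromatic carbon; in this assay compound 3 gives 4570 nM, which is a 1.5-fold higher number from compound 1 to compound 3 (0.17 log units; within the scatter). Compound 4 `COc1ccc(-n2cc(NC(=O)c3cccc(NS(=O)(=O)c4ccc(Cl)cc4)c3)cn2)cc1` has not yet been measured. It carries methoxy in place of methyl on an aromatic carbon, the same change as between compound 1 and compound 2, at the same place. Because a 14-fold higher number from compound 1 to compound 2 (1.13 log units; beyond the scatter), a step of a similar size is expected here, a 13-fold higher number from compound 3 to compound 4 (1.12 log units; beyond the scatter) in this assay. For compound 4 the expected value is 60000 nM, estimated to lie between 20000 nM and 180000 nM.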

Compound 4, half-maximal inhibitory concentration: 19700 nM
For compound 4 the middle estimate is 3.0-fold (0.48 log units) above the measured one; measured number below the stated range.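

Methoxy in place of methyl again raises the number in this assay, with a 4.3-fold higher number from compound 3 to compound 4 (0.63 log units; beyond the scatter), so the direction carries over to the core of compound 3, but the size does not: the same change on two cores in this assay, a 14-fold higher number (1.13 log units; beyond the scatter) from compound 1 to compound 2 and a 4.3-fold higher number (0.63 log units; beyond the scatter) from compound 3 to compound 4, 3.1-fold (0.50 log units) apart, beyond the scatter of two such steps Chloro in place of hydrogen also depends on its partner, giving a 2.1-fold lower number from compound 2 to compound 4 (0.33 log units; beyond the scatter) where methoxy is present, unlike the step seen where methyl is present: the same change on two cores in this assay, a 1.5-fold higher number (0.17 log units; within the scatter) from compound 1 to compound 3 and a 2.1-fold lower number (0.33 log units; beyond the scatter) from compound 2 to compound 4, 3.1-fold (0.50 log units) apart, beyond the scatter of two such steps These four compounds show that the two changes do not simply add up here, but they do not show why, or whether this holds on other cores.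

Going by these compounds, it remains open how an amine or an ethoxy group would compare with methyl and methoxy. Whether bromo in place of chloro would behave the same way is also unanswered.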